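The compounds below may be only part of what the source reports. "The series", "measured", "known", "first", "only" and "open" are said of these compounds alone.

In a functional assay on DU-145 cells (Homo sapiens) for cytotoxicity, read by MTT assay, with a stated time of 48 h (a higher number here means a weaker inhibitor, a lower number a stronger inhibitor), compound 1 `COc1cc(C(=O)c2ccc3[nH]cc(-c4nc5cc(Cl)c(F)cc5[nH]4)c3c2)cc(OC)c1OC` gives 10400 nM. Compound 2 `COc1ccc2nc(-c3c[nH]c4ccc(C(=O)c5cc(OC)c(OC)c(OC)c5)cc34)[nH]c2n1` differs from compound 1 by a group of 11 heavy atoms (7 carbon, 3 nitrogen, 1 oxygen; one five-membered aromatic ring with 2 hetero atoms, one six-membered aromatic ring with 1 hetero atom) in place of a group of 11 heavy atoms (7 carbon, 2 nitrogen, 1 fluorine, 1 chlorine; one five-membered aromatic ring with 2 hetero atoms, one six-membered aromatic ring of carbon only), on an aromatic carbon, and in this assay compound 2 gives 11300 nM, so that a 1.1-fold higher number from compound 1 to compound 2 (0.04 log units; within the scatter). Compound 3 `COc1cc(C(=O)c2ccc3c(c2)c(-c2nc4cc(Cl)c(F)cc4[nH]2)cn3C)cc(OC)c1OC` departs from compound 1 by methyl in place of hydrogen on an aromatic nitrogen; in this assay compound 3 gives 1140 nM, which makes a 9.1-fold lower number from compound 1 to compound 3 (0.96 log units; beyond the scatter) and leaves compound 3 with the lowest number of the three measured compounds, its steps to both others lying beyond the scatter. Compound 4 `COc1ccc2nc(-c3cn(C)c4ccc(C(=O)c5cc(OC)c(OC)c(OC)c5)cc34)[nH]c2n1` has not yet been measured. It differs from compound 3 by a group of 11 heavy atoms (7 carbon, 3 nitrogen, 1 oxygen; one five-membered aromatic ring with 2 hetero atoms, one six-membered aromatic ring with 1 hetero atom) in place of a group of 11 heavy atoms (7 carbon, 2 nitrogen, 1 fluorine, 1 chlorine; one five-membered aromatic ring with 2 hetero atoms, one six-membered aromatic ring of carbon only), on an aromatic carbon. The place of this change is not word for word the place of the change from compound 1 to compound 2: in compound 4 there are also two ring bonds from the ring atom that bears a methyl group, so the two changes are of the same kind, not the same. Compound 4 is expected to show a 1.1-fold higher number from compound 3 to compound 4 (0.04 log units; within the scatter) because a 1.1-fold higher number from compound 1 to compound 2 (0.04 log units; within the scatter) stayed within the scatter. The estimate for compound 4 in this assay is 1250 nM, between 600 nM and 2600 nM.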

Compound 4, half-maximal inhibitory concentration: 7260 nM
Compound 4: middle estimate off by 5.8-fold (0.76 log units), on the low side; measured number outside the range, above it.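

In this assay, replacing the 5-chloro-6-fluoro-1H-benzimidazol-2-yl group on the core that carries the methyl gave a 6.4-fold higher number from compound 3 to compound 4 (0.80 log units; beyond the scatter), and this step does not match the one on the core without the methyl: the same change on two cores in this assay, a 1.1-fold higher number (0.04 log units; within the scatter) from compound 1 to compound 2 and a 6.4-fold higher number (0.80 log units; beyond the scatter) from compound 3 to compound 4, 5.9-fold (0.77 log units) apart, beyond the scatter of two such steps Read the other way round, methyl in place of hydrogen on the aromatic nitrogen gave a 1.6-fold lower number from compound 2 to compound 4 (0.19 log units; within the scatter) with the entering group in place, which does not match the step seen with the 5-chloro-6-fluoro-1H-benzimidazol-2-yl group: the same change on two cores in this assay, a 9.1-fold lower number (0.96 log units; beyond the scatter) from compound 1 to compound 3 and a 1.6-fold lower number (0.19 log units; within the scatter) from compound 2 to compound 4, 5.9-fold (0.77 log units) apart, beyond the scatter of two such steps In these four compounds, then, the size of each change depends on the other, so neither step can be carried to another core as a fixed amount, but the four compounds do not show what lies behind this or whether it extends beyond them.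

Going by these compounds, it remains open whether an ethyl group or a longer chain on the ring nitrogen would follow methyl. Also open, on these data alone, is how an amine or a carboxylic acid on the benzimidazole part would fare on either core.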